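The source may hold more compounds than are shown below. What is called first, only, known or untested is meant among the compounds shown, and "the series" means these compounds.

Measured so far:
Compound 1, `COc1nc2ccc(Br)cc2cc1C(c1ccccc1)n1cc(-c2ccccc2F)nn1`, gives 14.1% in an ADME assay on HeLa cells (Homo sapiens) for cytotoxicity, read by sulforhodamine B assay, with a stated time of 48 h, tested at 10 uM; on this read-out higher numbers stand for more inhibition at the one concentration tested (going by the name of the read-out) and lower numbers for less inhibition.
Compound 2, `COc1nc2ccc(Br)cc2cc1C(c1ccccc1)n1cc(CO)nn1`, gives 0.25% in this assay.

Compound 2 has the lower of the two numbers measured, and its nearest neighbour on this read-out is compound 1, which lies beyond the scatter above it. Among the measured compounds shown here, the only measured step is a number 13.9 percentage points lower from compound 1 to compound 2 (beyond the scatter), and it is the one that bears on the question here, since the change now considered runs the other way: compound 3, `COc1nc2ccc(Br)cc2cc1C(c1ccccc1)n1cc(-c2cccc(F)c2)nn1`, carries 3-fluorophenyl in place of hydroxymethyl on an aromatic carbon. The group entering compound 3 is a fluorophenyl ring, as was the group that left in going from compound 1 to compound 2, differing only in where the fluorine sits on that ring. A return to a fluorophenyl ring is therefore expected to undo much of the drop seen in the measured step, giving a rise of modest size in this assay, a number 12.8 percentage points higher from compound 2 to compound 3 (beyond the scatter). For compound 3 the expected read-out in this assay is 13%, with a range from 3% to 25%.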

Compound 3, a percentage reported as inhibition, at one concentration (the size of the read-out at that concentration, not a potency): 9.04%
The estimate for compound 3 lay 4 percentage points above the measured number, within the range that was stated.
By their numbers in this assay, from the lowest: compounds 2, 3 and 1 (each within the scatter of the next, the first and the last beyond it).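

In this assay, replacing hydroxymethyl with 3-fluorophenyl on this aromatic carbon of the five-membered ring gives a number 8.8 percentage points higher from compound 2 to compound 3 (within the scatter), so a fluorophenyl ring at this position does not by itself guarantee a number that stands clear of the hydroxymethyl compound. Changing 2-fluorophenyl to 3-fluorophenyl gives a number 5.1 percentage points lower from compound 1 to compound 3 (within the scatter), which means that the two fluorophenyl compounds cannot be told apart on this read-out, and a different fluorine placement on the ring has shown no measurable consequence here. Of the three compounds, only compound 1 and compound 2 are separated beyond the scatter, and nothing shown here explains why the numbers fall as they do.

The three compounds leave open whether the fluorine contributes at all, since a plain phenyl ring would be needed to compare with the two fluorophenyl compounds. They also leave open how this position responds to groups of a different kind, such as an amine, a carboxylic acid or a longer chain, and whether any of these would move the number well beyond the scatter in either direction.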